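A few compounds are considered here, and "the series" means these few. Any claim that something is new, unique, unknown or untested is made for them only; others in the source may bear on it.

Three compounds have been measured in an assay on isolated protein for inhibition of tyrosine-protein kinase receptor UFO (Homo sapiens), read by ELISA; on this read-out higher numbers stand for weaker inhibition and lower numbers for stronger inhibition:

Compound 1 `Cn1cc(-c2ccc(NC(=O)c3cn(CC4CCCO4)cc(-c4ccc(F)cc4)c3=O)cc2)c2c(N)ncnc21` gives 1.2 nM.
Compound 2 `Cn1cc(-c2ccc(NC(=O)c3cn(CC4CCOCC4)cc(-c4ccc(Cl)cc4)c3=O)cc2)c2c(N)ncnc21` gives 0.2 nM.
Compound 3 `Cc1cc(-c2cn(C)c3ncnc(N)c23)ccc1NC(=O)c1cn(CC2CCOCC2)cc(-c2ccc(F)cc2)c1=O` gives 4 nM.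

Among these three numbers compound 1 stands second highest. Compound 3 gives a higher number than compound 1, a gap beyond the usual scatter, while compound 2 gives a lower number, also beyond the scatter. No single-point comparison exists among the measured compounds, so these values are taken as they stand.

Compound 4 `Cn1cc(C(=O)Nc2ccc(-c3cn(C)c4ncnc(N)c34)cc2)c(=O)c(-c2ccc(F)cc2)c1` has not yet been measured in this assay. It differs from compound 1 in one place: hydrogen in place of oxolan-2-yl on a saturated chain carbon bound to an aromatic nitrogen. Cut one bond further out, the same difference reads (oxolan-2-yl)methyl to methyl. The measured set holds no comparison that isolates this part of the molecule, so the direction of the step cannot be read from a measured pair. The author expects compound 4 to be a somewhat weaker inhibitor than compound 1, with a step of a 4.2-fold higher number from compound 1 to compound 4 (0.62 log units; beyond the scatter) estimated to lie beyond the scatter. Compound 4 is therefore estimated at 5 nM, with an expected range from 1.5 nM to 20 nM.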

Compound 4, half-maximal inhibitory concentration: 5 nM
Compound 4: the middle estimate sits on the measured number at the digits printed, and the stated range covers the measured number.
By their numbers in this assay, from the lowest: compound 2; then compound 1; then compounds 3 and 4 (each within the scatter of the next).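

Going from (oxolan-2-yl)methyl to methyl in this assay gives a 4.2-fold higher number from compound 1 to compound 4 (0.62 log units; beyond the scatter), the first measured comparison that isolates this position. The oxolan-2-yl on the saturated chain carbon bound to an aromatic nitrogen therefore counts for something in this series, yet the step is modest, and compound 4, which lacks that ring, still gives 5 nM in this assay. Nothing at hand accounts for the size or direction of this step.

The compounds shown leave open whether a plain longer chain such as propyl would match the (oxolan-2-yl)methyl group of compound 1, or whether it is the ring that counts. They also leave open how an amine or a carboxylic acid carried on that chain would read in this assay on the same core.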